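The compounds below may be only part of what the source reports. "The series", "measured", "known", "first", "only" and "open" are said of these compounds alone.

Series in a functional assay on HT-1080 cells (Homo sapiens) for antiproliferative activity, read by MTT assay, with a stated time of 72 h; a lower number here means a stronger inhibitor, a higher number a weaker inhibitor:
compound 1 `CCOC(=O)c1cc(-c2cc(OC)c(OC)c(OC)c2)c(-c2ccc(OC)c([N+](=O)[O-])c2)s1`: 12700 nM
compound 2 `CCOC(=O)c1cc(-c2cc(OC)c(OC)c(OC)c2)c(-c2ccc(OC)c(OCc3ccccc3)c2)s1`: > 100000 nM (a limit)
compound 3 `CCOC(=O)c1cc(-c2cc(OC)c(OC)c(OC)c2)c(-c2ccc(OC)c(O)c2)s1`: 3220 nM

Compound 2 has no number and stands only at the limit of > 100000 nM in this assay, at which 1 of the 3 values shown sits, in these data. Compound 4 `COc1ccc(-c2sccc2-c2cc(OC)c(OC)c(OC)c2)cc1OCc1ccccc1` keeps the benzyloxy group of compound 2 and loses the ester. The change is hydrogen in place of ethoxycarbonyl on an aromatic carbon and amounts to hydrogen in place of ethoxycarbonyl on an aromatic carbon.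

Among the compounds with values here, no measured step touches the ethoxycarbonyl group, so none gives a direct size for this change. The three steps all concern another place, where a 3.9-fold lower number from compound 1 to compound 3 (0.60 log units; beyond the scatter) is modest, an at least 7.8-fold higher number from compound 1 to compound 2 (0.89 log units; beyond the scatter) is at least modest and an at least 31-fold lower number from compound 2 to compound 3 (1.49 log units; beyond the scatter) is large. They bear on the change only indirectly: the benzyloxy group stays in compound 4, and an at least 31-fold lower number from compound 2 to compound 3 (1.49 log units; beyond the scatter) sets that group well behind the free hydroxy group. Compound 4 is therefore expected to stay weak in this assay, with at most a moderate move towards a lower number and a real chance of a second limit. The estimated change is an at least 1.6-fold lower number from compound 2 to compound 4 (0.22 log units; that floor lies within the scatter) in this reading. For compound 4 the expected value is 60000 nM as a rough estimate. The estimated range for compound 4 runs from 12000 nM to 100000 nM in this assay on this reasoning.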

Compound 4, half-maximal inhibitory concentration: > 100000 nM
Compound 4: a limit, no number; the forecaster's own chance of this, stated with the estimate: 50%; at least 1.6-fold (0.22 log units) between middle value and limit.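

In this assay compound 4 gives > 100000 nM, a limit, and compound 2 also stands at a limit, so the step between them, hydrogen in place of ethoxycarbonyl on an aromatic carbon, cannot be read: the limit of > 100000 nM in this assay, at which 2 of the 4 values shown sit. The compounds shown leave open what size this change has, in either direction, in this assay.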